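Adding a Methoxy Group: What Compound 3 Might Show

The source may hold more compounds than are shown below. What is called first, only, known or untested is meant among the compounds shown, and "the series" means these compounds.

Of the compounds shown here, two have so far been tested in an assay on isolated protein for displacement of a labelled ligand from metabotropic glutamate receptor 5 (Homo sapiens), with a stated time of 60 min, tested at 1 uM; on this read-out higher numbers stand for more inhibition at the one concentration tested (going by the name of the read-out) and lower numbers for less inhibition. Compound 1 `COc1cccc(S(=O)(=O)c2cnc3ccc(OC)cc3c2N2CCC(C)CC2)c1` gives 0%, while compound 2 `Cc1ccc2ncc(S(=O)(=O)c3ccccc3)c(N3CCC(C)CC3)c2c1` gives 67%, the higher of the two numbers and a gap beyond the usual scatter. Compound 3 `COc1cccc(S(=O)(=O)c2cnc3ccc(C)cc3c2N2CCC(C)CC2)c1` has not been measured. It differs from compound 2 in one place: methoxy in place of hydrogen on an aromatic carbon. Among the measured compounds shown here, no single-change step has yet been measured, so the direction is uncertain; a methoxy group is also present in compound 1, which differs from compound 2 in several places, yet compound 1 gave 0%. A moderate fall in inhibition is expected, a number 27 percentage points lower from compound 2 to compound 3 (beyond the scatter). Compound 3 is estimated at 40%, between 5% and 75%.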

Compound 3, a percentage reported as inhibition, at one concentration (the size of the read-out at that concentration, not a potency): 96%
Estimate against measurement, compound 3: 56 percentage points below, and the stated range ends below it.
By their numbers in this assay, from the lowest: compound 1; then compound 2; then compound 3.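

In this assay the change from phenyl to 3-methoxyphenyl gives a number 29 percentage points higher from compound 2 to compound 3 (beyond the scatter) and so goes with more inhibition, not less. With the 3-methoxyphenyl kept, methyl in place of methoxy on an aromatic carbon of the shared core gives a number 96 percentage points higher from compound 1 to compound 3 (beyond the scatter) as the second single change. The low number of compound 1 therefore goes with the methoxy on the core, not with the one on the phenyl.

Nothing available explains either step. As far as these compounds go, whether an ethoxy or a hydroxy group in the same place would keep this gain remains open.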